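The source may hold more compounds than are shown below. What is called first, only, known or untested is meant among the compounds shown, and "the series" means these compounds.

Of the compounds shown here, three sharing one core have been read so far in a physicochemical assay for lipophilicity; on this read-out higher numbers stand for higher lipophilicity and lower numbers for lower lipophilicity. Compound 1 (`C[C@H]1CC[C@@H]2[C@@H](OC(=O)[C@]23CC(c2c(Cl)cccc2Cl)=NO3)[C@]2(C)C(=O)C=C[C@@]12O`) gives 2.67, compound 2 (`C[C@H]1CC[C@@H]2[C@@H](OC(=O)[C@]23CC(c2ccc(Cl)cc2)=NO3)[C@]2(C)C(=O)C=C[C@@]12O`) gives 2.09 and compound 3 (`C[C@H]1CC[C@@H]2[C@@H](OC(=O)[C@]23CC(c2ccc([N+](=O)[O-])cc2)=NO3)[C@]2(C)C(=O)C=C[C@@]12O`) gives 1.37. Compound 3 is the lowest of the three, and its gaps to both others lie beyond the scatter.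

Compound 4 (`COc1cc(C2=NO[C@]3(C2)C(=O)O[C@@H]2[C@H]3CC[C@H](C)[C@]3(O)C=CC(=O)[C@@]23C)ccc1O`) follows from compound 3 by a single exchange, with 4-hydroxy-3-methoxyphenyl in place of 4-nitrophenyl on a carbon with a double bond to nitrogen.

Among the measured compounds shown here, no measured step covers this exchange directly. The closest guides are changes at the same place: the modest a number 0.58 log units lower from compound 1 to compound 2 (beyond the scatter), the modest a number 0.72 log units lower from compound 2 to compound 3 (beyond the scatter) and the large a number 1.30 log units lower from compound 1 to compound 3 (beyond the scatter). For the measured compounds named here, no measured compound carries the entering group, so these steps indicate a scale rather than a firm direction. Starting from compound 3 at 1.37, a small downward move is expected, smaller than any of these steps, and the range is kept wide. The expected change is a number 0.17 log units lower from compound 3 to compound 4 (within the scatter). For compound 4 the estimated value is 1.2, with an expected range of 0.7 to 1.7.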

Compound 4, partition coefficient: 0.75
Beside the measured number, compound 4's estimate is 0.45 log units above it; measured number inside the range.
By their numbers in this assay, from the lowest: compound 4; then compound 3; then compound 2; then compound 1.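

At this position on the shared core, 4-hydroxy-3-methoxyphenyl gives the lowest reading so far in this assay, with a number 0.62 log units lower from compound 3 to compound 4 (beyond the scatter) and further gaps of a number 1.34 log units lower from compound 2 to compound 4 (beyond the scatter) and a number 1.92 log units lower from compound 1 to compound 4 (beyond the scatter) across the series. The exchange from 4-nitrophenyl keeps the heavy-atom count and the single aromatic ring, so a clear drop occurs here without any change in those counts, while the entering group adds a hydrogen-bond donor that the leaving group lacks. Nothing at hand gives a measured reason for this drop. Whether the hydroxy or the methoxy part of the entering group carries the step stays open: no compound shown has either one alone on the phenyl ring. Also open, on these data alone, is how an amine or a carboxylic acid would read at this position.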